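Changing the carbamate end of a shared core

The compounds below may be only part of what the source reports. "The series", "measured", "known", "first", "only" and "open" are said of these compounds alone.

Three compounds share one core and differ at two ends. Compound 1 `CCc1nc2c(C)cc(-c3ccc(CN4CCC(O)CC4)cc3)cn2c1NC(=O)OCc1cc(Cl)cc(Cl)c1`, compound 2 `CCc1nc2c(C)cc(-c3ccc(CN4CCC[C@H]4CO)cc3)cn2c1NC(=O)OCc1cc(Cl)cc(Cl)c1` and compound 3 `CCc1nc2c(C)cc(-c3ccc(CN4CCN(C)CC4)cc3)cn2c1NC(=O)OCc1cc(Cl)cc(Cl)c1` all carry the same 3,5-dichlorobenzyl carbamate and differ only in the ring attached to the benzylic carbon on the other side. In a functional assay on MCF7 cells (Homo sapiens) for inhibition, read by MTT assay, with a stated time of 72 h (on this read-out higher numbers stand for weaker inhibition and lower numbers for stronger inhibition), compound 1 gives 5320 nM. In this assay compound 2 gives "nd" (no result reported), so no number is known for it. In this assay compound 3 gives 5780 nM. Among the compounds with values here, only two numbers are known, and compound 3 cannot be separated from compound 1, because a 1.1-fold higher number from compound 1 to compound 3 (0.04 log units; within the scatter).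

Compound 4 `CCc1nc2c(C)cc(-c3ccc(CN4CCN(C)CC4)cc3)cn2c1NC(=O)OCc1ccc(C(F)(F)F)cc1` keeps the 4-methylpiperazin-1-yl end of compound 3 and alters the carbamate end: 4-(trifluoromethyl)phenyl in place of 3,5-dichlorophenyl on a saturated chain carbon bound to an oxygen next to a carbonyl group. Within the data shown here, no measured step touches this part of the molecule; the single known step concerns the other end and tells nothing about the benzyl carbamate. With no guidance from the data, compound 4 is expected to give a number close to that of compound 3, with a broad range to reflect the missing information. In this assay compound 4 is estimated at 5800 nM, between 1500 nM and 22000 nM. That estimate corresponds to an expected step of a 1.0-fold higher number from compound 3 to compound 4 (0.00 log units; within the scatter), which is no change beyond the scatter.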

Compound 4, half-maximal inhibitory concentration: > 20000 nM
Compound 4: only a limit was reported (the forecaster's own chance of this, stated with the estimate: 10%); middle value at least 3.4-fold (0.53 log units) away from the limit.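

Within the data shown here, the carbamate end, which no earlier step touched, turns out to matter: 4-(trifluoromethyl)phenyl in place of 3,5-dichlorophenyl on a saturated chain carbon bound to an oxygen next to a carbonyl group gives an at least 3.4-fold higher number from compound 3 to compound 4 (0.53 log units; beyond the scatter) in this assay, which means weaker inhibition. Among these compounds, the only earlier step, a 1.1-fold higher number from compound 1 to compound 3 (0.04 log units; within the scatter), concerned the ring at the other end of the molecule, so this is the first change that moves the read-out beyond the scatter. From the compounds shown here alone, for compound 4 the assay gives only a limit and not a number, so the true size of this step remains unknown: the limit of > 20000 nM in this assay, at which 1 of the 4 values shown sits.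

This single swap removes two chlorine atoms and brings in a trifluoromethyl group in one move, so the compounds shown cannot separate the loss of the chlorines from the gain of the trifluoromethyl group. They also leave open how a plain benzyl or a 4-chlorobenzyl group would read at this position, and whether the same swap would have a similar effect with the 4-hydroxypiperidin-1-yl end of compound 1.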